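The source may report more compounds than this note shows. Statements on the series, on what has been measured and on what is new or still open speak of the compounds shown alone.

In an ADME assay on MRC5 cells (Homo sapiens) for inhibition, with a stated time of 72 h (on this read-out lower numbers stand for an effect already at smaller amounts and higher numbers for an effect only at larger amounts of compound), three compounds sharing one core have been measured. Compound 3 `COc1cccc(OC)c1C(=O)Nc1c[nH]nc1C(=O)NC1CCCCCC1` gives 42000 nM on this read-out. Compound 1 `COc1cccc(OC)c1C(=O)Nc1c[nH]nc1C(=O)NCc1ccccc1` gives 50000 nM here, and the step of a 1.2-fold lower number from compound 1 to compound 3 (0.08 log units; within the scatter) shows that the two cannot be told apart. Compound 2 `COc1cccc(OC)c1C(=O)Nc1c[nH]nc1C(=O)NCCCOC(C)C` returns only a limit, > 50000 nM, and no exact number.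

Compound 4 `COCCNC(=O)c1n[nH]cc1NC(=O)c1c(OC)cccc1OC`, not yet measured, carries 2-methoxyethyl in place of cycloheptyl on an amide-type nitrogen and keeps the rest of compound 3 unchanged.

Two measured steps change the same nitrogen. Going by these compounds, one is the step of a 1.2-fold lower number from compound 1 to compound 3 (0.08 log units; within the scatter) and the other, which involves a chain holding an oxygen as compound 4 does, is an at least 1.1-fold lower number from compound 2 to compound 3 (0.07 log units; that floor lies within the scatter), whose full size stays open. Neither shows a change beyond the scatter, so no clear shift is expected from the new chain, though a small move to higher numbers would fit compound 2.

The expected change is a 1.2-fold higher number from compound 3 to compound 4 (0.08 log units; within the scatter) in this assay as an estimate. For compound 4 the estimate is 50000 nM with a range of 30000 nM to 70000 nM and the result may come back only as a limit.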

Compound 4, half-maximal effective concentration: > 50000 nM
Compound 4 ended at the assay's limit; the forecaster's own chance of this, stated with the estimate: 60%; the middle value sits exactly at the limit.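

Going by these compounds, with 2-methoxyethyl in place of cycloheptyl on an amide-type nitrogen in this assay, the result is an at least 1.1-fold higher number from compound 3 to compound 4 (0.07 log units; that floor lies within the scatter), so only a floor is known and the true size of the step stays open. With methoxymethyl in place of phenyl on a saturated chain carbon bound to an amide-type nitrogen, the result is a number no lower from compound 1 to compound 4 (the limit leaves the size open). The step from compound 2 to compound 4 cannot be read. Among these four compounds, the two with an open chain holding an oxygen, compound 2 and compound 4, both end at a limit of the assay, while the two with a ring on this nitrogen, compound 1 and compound 3, give exact numbers: the limit of > 50000 nM in this assay, at which 2 of the 4 values shown sit.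

The compounds shown cannot separate the oxygen from the absence of a ring, which a plain butyl chain on the same nitrogen could do. On these data alone, how an amine or a carboxylic acid at the end of this chain would read also stays open.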